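One aryl swap, measured once and expected again

This account rests on a few compounds, and the source may have more. Where it says the series, first, only, none or still open, it means among the compounds named here.

Compound 1, `COc1ccc(-c2nc(C)c(C(=O)CSc3nc(-c4ccc(Cl)cc4)c(C#N)c(=O)[nH]3)s2)cc1`, in a functional assay on U-87MG ATCC cells for antiproliferative activity against U-87 MG (Homo sapiens), read by MTT assay, with a stated time of 48 h, tested at 50 uM (on this read-out higher numbers stand for a weaker effect at the one concentration tested and lower numbers for a stronger effect), gives 48%.
Compound 2, `COc1ccc(-c2nc(C)c(C(=O)CSc3nc(-c4ccc(OC)c(OC)c4)c(C#N)c(=O)[nH]3)s2)cc1`, in this assay gives 22.2%.
Compound 3, `COc1ccc(-c2nc(SCC(=O)c3sc(-c4ccccc4)nc3C)[nH]c(=O)c2C#N)cc1OC`, in this assay gives 21.4%.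

Of the compounds shown here, three have been measured, and a fourth, compound 4 `Cc1nc(-c2ccccc2)sc1C(=O)CSc1nc(-c2ccc(Cl)cc2)c(C#N)c(=O)[nH]1`, has not. Compound 4 comes from compound 3 through one change, (4-chlorophenyl in place of 3,4-dimethoxyphenyl on an aromatic carbon). The same change, with the same printed surroundings, links two measured compounds: 4-chlorophenyl in place of 3,4-dimethoxyphenyl on an aromatic carbon. That measured step was a number 25.8 percentage points higher from compound 2 to compound 1 (beyond the scatter), a move toward a weaker effect at the one concentration tested.

The two cores on which the change is made are not identical. Compound 3 differs from compound 2 in one spot, (hydrogen in place of methoxy on an aromatic carbon), and that difference made a number 0.8 percentage points lower from compound 2 to compound 3 (within the scatter), so compound 2 and compound 3 cannot be told apart in this assay. With the surroundings of the swap identical in words, and the only other difference between the two cores being small in effect, the earlier step is the best available guide.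

Compound 4 is therefore expected to sit near compound 1, with a step of about a number 25.6 percentage points higher from compound 3 to compound 4 (beyond the scatter) from compound 3, because the matching step gave a number 25.8 percentage points higher from compound 2 to compound 1 (beyond the scatter). The estimate for compound 4 in this assay is 47%, with a range from 32% to 62%, the width reflecting that this rests on a single measured pair.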

Compound 4, a percentage reported as activity, at one concentration (the size of the read-out at that concentration, not a potency): 63.4%
Estimate against measurement, compound 4: 16.4 percentage points below; measured number outside the range, above it.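

In this assay, the swap to 4-chlorophenyl from 3,4-dimethoxyphenyl moved the number toward a weaker effect on both cores, but on the new core it gave a number 42 percentage points higher from compound 3 to compound 4 (beyond the scatter), and the size of the step did not carry over: the same change on two cores in this assay, a number 25.8 percentage points higher (beyond the scatter) from compound 2 to compound 1 and a number 42 percentage points higher (beyond the scatter) from compound 3 to compound 4, 16.2 percentage points apart, beyond the scatter of two such steps. The same four compounds can be read along the other change, hydrogen in place of methoxy, which made no telling difference between the two dimethoxyphenyl compounds yet gave a number 15.4 percentage points higher from compound 1 to compound 4 (beyond the scatter) once 4-chlorophenyl was present, so the two changes do not simply add up: the same change on two cores in this assay, a number 0.8 percentage points lower (within the scatter) from compound 2 to compound 3 and a number 15.4 percentage points higher (beyond the scatter) from compound 1 to compound 4, 16.2 percentage points apart, beyond the scatter of two such steps. This shows that in these two pairs the direction of the swap held while its size depended on the rest of the molecule, but two pairs make no rule, and the numbers do not say why the steps differ.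

The compounds shown leave open whether the same dependence appears when the 4-chlorophenyl is replaced by a ring carrying an amine or a carboxylic acid, or when the methoxy is replaced by a longer chain. With each compound read at a single concentration, they also leave open whether these gaps would hold at other concentrations, since they describe only a stronger or weaker effect at the one concentration tested.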